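Amide-aryl methyl addition in the dimethylphenyl series

This account rests on a few compounds, and the source may have more. Where it says the series, first, only, none or still open, it means among the compounds named here.

Measured compounds in a functional assay on K562 cells (Homo sapiens) for cytotoxicity, read by WST assay, with a stated time of 72 h; on this read-out lower numbers stand for stronger inhibition and higher numbers for weaker inhibition:
compound 1 `COc1cc2c(Nc3nc4ccc(C(=O)Nc5c(C)cccc5C)cc4s3)ncnc2cc1OCCCN1CCCC1` gives 15700 nM
compound 2 `COc1cc2c(Nc3nc4ccc(C(=O)Nc5c(C)cccc5C)cc4s3)ncnc2cc1OCCCN1CCCCC1` gives 13700 nM
compound 3 `COc1cc2c(Nc3nc4ccc(C(=O)Nc5c(C)cccc5C)cc4s3)ncnc2cc1OCCCN1CCC(C)CC1` gives 15800 nM

Compound 2 gives the lowest of the three numbers, but the gaps are small: a 1.1-fold lower number from compound 1 to compound 2 (0.06 log units; within the scatter) and a 1.2-fold higher number from compound 2 to compound 3 (0.06 log units; within the scatter), so the three compounds cannot be separated on these data.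

Compound 4 `COc1cc2c(Nc3nc4ccc(C(=O)Nc5c(C)cc(C)cc5C)cc4s3)ncnc2cc1OCCCN1CCCCC1` differs from compound 2 by methyl in place of hydrogen on an aromatic carbon. For the measured compounds named here, none of the measured steps touches this part of the structure; the only methyl addition seen, a 1.2-fold higher number from compound 2 to compound 3 (0.06 log units; within the scatter), sits on the saturated ring at the other end of the molecule and changed nothing beyond the scatter. The change from pyrrolidinyl to piperidinyl, a 1.1-fold lower number from compound 1 to compound 2 (0.06 log units; within the scatter), was likewise flat. There is therefore no measured basis for a step of any size in either direction, and in this assay compound 4 is expected to sit close to compound 2, the expected step being a 1.0-fold higher number from compound 2 to compound 4 (0.01 log units; within the scatter). Compound 4 is estimated at 14000 nM, with a range of 6000 nM to 33000 nM.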

Compound 4, half-maximal inhibitory concentration: 9300 nM
For compound 4 the middle estimate is 1.5-fold (0.18 log units) above the measured one, and the stated range covers the measured number.
By their numbers in this assay, from the lowest: compounds 4, 2, 1 and 3 (each within the scatter of the next).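

In this assay, the change from 2,6-dimethylphenyl to 2,4,6-trimethylphenyl gives a 1.5-fold lower number from compound 2 to compound 4 (0.17 log units; within the scatter), so a methyl on this aromatic carbon, para to a large group, is tolerated without a step that can be told from the scatter. For the compounds shown here, compounds 1, 2 and 3 all carry the 2,6-dimethylphenyl group and vary only the saturated ring, so this is the only reading here from the aryl end of the amide, and it too gives no separation. No measured property in hand bears on this result.

The compounds shown leave open whether a methoxy group, a chlorine atom or an amine at this position would give a step beyond the scatter. Also open, as far as these compounds go, is whether the 2,4,6-trimethylphenyl group would read the same with the pyrrolidin-1-yl or 4-methylpiperidin-1-yl side chains.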